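The source may report more compounds than this note shows. Statements on the series, on what has been measured and on what is new or still open speak of the compounds shown alone.

Measured in a functional assay on SNB-78 cells (Homo sapiens) for inhibition, read by colorimetric assay and sulforhodamine B assay, with a stated time of 48 h; on this read-out lower numbers stand for stronger inhibition of growth and higher numbers for weaker inhibition of growth:
- compound 1 `CCCCCCCCCCCC[C@@H](O)[C@H]1CC[C@H]([C@H](O)CCCCCCCCCCNC(=O)c2cccs2)O1`: 2290 nM
- compound 2 `CCCCCCCCCCCC[C@@H](O)[C@H]1CC[C@H]([C@H](O)CCCCCCCCCCNC(=O)c2cncs2)O1`: 100000 nM
- compound 3 `CCCCCCCCCCCC[C@@H](O)[C@H]1CC[C@H]([C@H](O)CCCCCCCCCCNC(=O)c2ccsc2)O1`: 100000 nM

Compound 3 stands level with compound 2, the two sharing the highest of the three numbers, well apart from compound 1. The next structure, compound 4 `CCCCCCCCCCCC[C@@H](O)[C@H]1CC[C@H]([C@H](O)CCCCCCCCCCNC(=O)c2ccnn2C)O1`, keeps the shared core and the amide and alters only the ring: 1-methyl-1H-pyrazol-5-yl in place of thiophen-3-yl on a carbonyl carbon. In words, this is 1-methyl-1H-pyrazol-5-yl in place of thiophen-3-yl on a carbonyl carbon.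

All three measured steps concern this same place. Two are large, and both leave thiophen-2-yl: a 44-fold higher number from compound 1 to compound 2 (1.64 log units; beyond the scatter) and a 44-fold higher number from compound 1 to compound 3 (1.64 log units; beyond the scatter). The third joins the two rings that replaced it, with no change at the digits printed from compound 2 to compound 3 (within the scatter). Compound 4 also lacks thiophen-2-yl, so it is expected to sit with compound 2 and compound 3 rather than with compound 1. No step beyond the scatter is therefore expected in this assay, and the estimate amounts to a 1.7-fold lower number from compound 3 to compound 4 (0.22 log units; within the scatter). Going by the values given here, still, only three rings have been measured, and compound 1 at 2290 nM shows that a ring at this place can give a much lower number, so the expected range stays open on that side. For compound 4 the estimated value is 60000 nM, with an expected range from 6000 nM to 100000 nM.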

Compound 4, concentration for 50% growth inhibition: 100000 nM
Compound 4: middle estimate off by 1.7-fold (0.22 log units), on the low side; the measured number falls inside the stated range.
By their numbers in this assay, from the lowest: compound 1; then compounds 2, 3 and 4 (each within the scatter of the next).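

In this assay, the change to 1-methyl-1H-pyrazol-5-yl on the carbonyl carbon gives a step of the same kind as the one between the two earlier replacement rings (no change at the digits printed from compound 3 to compound 4 (within the scatter); no change at the digits printed from compound 2 to compound 4 (within the scatter)), while the gap to the thiophen-2-yl amide is again large (a 44-fold higher number from compound 1 to compound 4 (1.64 log units; beyond the scatter)). The earlier replacements both contained sulfur, so this result adds a ring with no sulfur, with two nitrogens and with one more heavy atom than thiophen-3-yl, and that different ring still stays with compound 2 and compound 3; among these four amides, only compound 1 stands apart. No measurement offered here explains why thiophen-2-yl differs from the other rings at this place.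

The compounds shown leave open whether any other group on this carbonyl carbon, such as furan-2-yl or phenyl, would share the number of compound 1 or fall with the other three. They also leave open whether a methyl group added to the thiophen-2-yl ring would keep that number.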